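The source may hold more compounds than are shown below. What is called first, only, known or untested is meant among the compounds shown, and "the series" means these compounds.

In a functional assay on MDA-MB-231 cells (Homo sapiens) for antiproliferative activity, read by CCK-8 assay, with a stated time of 72 h (on this read-out lower numbers stand for stronger inhibition and higher numbers for weaker inhibition), compound 3 `CC1=NN(c2ccccc2)C(=O)C12C=CC(=O)C=C2c1cccc(C)c1` gives 85800 nM. Compound 1 `CC1=NN(c2ccc(C)cc2)C(=O)C12C=CC(=O)C=C2c1cccc(C)c1`, in this assay, gives 19400 nM. The two differ by a single change, (methyl in place of hydrogen on an aromatic carbon), and the step of a 4.4-fold lower number from compound 3 to compound 1 (0.65 log units; beyond the scatter) is the one direct reading available for this change among the compounds shown.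

Compound 2 `CC1=NN(c2ccc(Cl)cc2)C(=O)C12C=CC(=O)C=C2c1ccccc1` belongs to a different core, and the difference between the core of compound 2 and the core of compound 3 is not broken down here. For compound 2 this assay reports only a limit, > 100000 nM, and not a number, which is the limit (the limit of > 100000 nM in this assay, at which 1 of the 3 values shown sits).

Compound 4 `CC1=NN(c2ccc(Cl)cc2)C(=O)C12C=CC(=O)C=C2c1ccc(C)cc1` has not yet been measured in this assay. It differs from compound 2 by methyl in place of hydrogen on an aromatic carbon, the same change that separates compound 3 from compound 1, placed at the same kind of position. If the change were to behave as it did in the measured pair, the step from compound 2 to compound 4 is expected to be about an at least 1.4-fold lower number from compound 2 to compound 4 (0.15 log units; that floor lies within the scatter), resting on the step of a 4.4-fold lower number from compound 3 to compound 1 (0.65 log units; beyond the scatter) and on the fact that compound 2 sits at a limit rather than at a number. On that basis compound 4 is expected to give about 70000 nM in this assay, with a plausible range from 20000 nM to 100000 nM.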

Compound 4, half-maximal inhibitory concentration: 14300 nM
Beside the measured number, compound 4's estimate is 4.9-fold (0.69 log units) above it; the whole stated range lies above it.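

In this assay, methyl in place of hydrogen on an aromatic carbon goes with a lower number on both cores shown: the new step is an at least 6.9-fold lower number from compound 2 to compound 4 (0.84 log units; beyond the scatter), the earlier one is a 4.4-fold lower number from compound 3 to compound 1 (0.65 log units; beyond the scatter), and neither pair goes against this direction, so on these two pairs the direction of the change carries from one core to the other. Compound 2 stands only at a limit of this assay, > 100000 nM, and not at a number, so the new step gives a floor for the size of the change on its core and not the size itself. The direction therefore carries over in these pairs, but nothing shows that the size does, and two pairs make no rule for the whole series: the same change on two cores in this assay, a 4.4-fold lower number (0.65 log units; beyond the scatter) from compound 3 to compound 1 and an at least 6.9-fold lower number (0.84 log units; beyond the scatter) from compound 2 to compound 4; the limit leaves it open whether they differ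

The compounds shown leave open how the change would behave on any further core, and whether the methyl group is special or whether an ethyl group, a methoxy group, an amine or a carboxylic acid in the same place would go with a lower number too. They also leave open what lies behind the step, as they give only this one read-out in one cell line and nothing on how the compounds act.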